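Replacing a Sulfur Link With a Benzylamine on the Core

The source may hold more compounds than are shown below. What is called first, only, known or untested is meant among the compounds shown, and "the series" means these compounds.

Compound 2 `Nc1cc(N)c2nc(-c3ccccc3)c(Sc3ccc(F)cc3)nc2c1` holds the higher of the two numbers recorded in a functional assay on SR cells (Homo sapiens) for inhibition, read by sulforhodamine B assay, with a stated time of 48 h; on this read-out higher numbers stand for weaker inhibition of growth and lower numbers for stronger inhibition of growth: compound 2 gives 35500 nM, while compound 1 `CCOC(=O)[C@H](CCC(=O)O)NC(=O)c1ccc(Sc2nc3cc(N)cc(N)c3nc2-c2ccccc2)cc1` gives 7760 nM, a gap that lies beyond the usual scatter. Compound 3 `Nc1cc(N)c2nc(-c3ccccc3)c(NCc3ccc(F)cc3)nc2c1` keeps the shared core and alters one group: (4-fluorobenzyl)amino in place of (4-fluorophenyl)sulfanyl on an aromatic carbon. Among the compounds with values here, no measured pair shows this change, so a modest step in either direction, or none beyond the scatter, would fit what is known. For compound 3 the expected value in this assay is 25000 nM, within 8000 nM to 80000 nM. This estimate means an expected step of a 1.4-fold lower number from compound 2 to compound 3 (0.15 log units; within the scatter).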

Compound 3, concentration for 50% growth inhibition: 4070 nM
For compound 3 the middle estimate is 6.1-fold (0.79 log units) above the measured one; the measured number lies below the stated range.
By their numbers in this assay, from the lowest: compounds 3 and 1 (each within the scatter of the next); then compound 2.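

Exchanging (4-fluorophenyl)sulfanyl for (4-fluorobenzyl)amino on the aromatic carbon next to the ring nitrogen gives an 8.7-fold lower number from compound 2 to compound 3 (0.94 log units; beyond the scatter) in this assay and so shows that the read-out responds to this change at this position. The entering group differs from the leaving one in its link and in its hydrogen-bond donor, but no measurement on hand accounts for the step.

The compounds shown leave open whether the nitrogen link or the extra carbon carries the step. A phenylamino group or a benzyloxy group at this position would separate the two.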